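From 3-chlorophenyl to 2-chloro-4-cyanophenyl: expected oral exposure

The source may hold more compounds than are shown below. What is called first, only, known or untested is meant among the compounds shown, and "the series" means these compounds.

In an ADME assay on the whole organism for pharmacokinetics, with Mus musculus as the target, at a dose of 10 mg/kg by the oral route (on this read-out higher numbers stand for higher exposure at the dose given and lower numbers for lower exposure), compound 3 (`CC/C(=C(/c1ccc(/C=C/C(=O)O)cc1)c1ccc2[nH]ncc2c1)c1cccc(Cl)c1`) gives 11000 ng.h/mL as its reading. That lies within the usual scatter of compound 2 (`CC/C(=C(/c1ccc(/C=C/C(=O)O)cc1)c1ccc2[nH]ccc2c1)c1ccccc1`) at 9400 ng.h/mL on the same read-out, while compound 1 (`CC/C(=C(/c1ccc(/C=C/C(=O)O)cc1)c1ccc2[nH]c(=O)oc2c1)c1ccccc1`) stands lower at 3000 ng.h/mL in this small set.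

Compound 4 (`CC/C(=C(/c1ccc(/C=C/C(=O)O)cc1)c1ccc2[nH]ncc2c1)c1ccc(C#N)cc1Cl`) differs from compound 3 in one place, with 2-chloro-4-cyanophenyl in place of 3-chlorophenyl on a double-bonded chain carbon bound to a double-bonded chain carbon and a saturated chain carbon and the rest of the structure shared.

Among the compounds with values here, the only measured step at a single place, a 3.1-fold higher number from compound 1 to compound 2 (0.50 log units; beyond the scatter), is beyond the scatter but exchanges a different group, so it gives no direct measure of this replacement. Within the data shown here, no measured compound carries the nitrile. The expectation therefore rests on compound 3 at 11000 ng.h/mL as its anchor, and no step beyond the scatter is expected in this assay for this change. The estimated step is a 1.2-fold lower number from compound 3 to compound 4 (0.09 log units; within the scatter) on this read-out. For compound 4 the estimate is 9000 ng.h/mL, with an expected range from 3500 ng.h/mL to 22000 ng.h/mL on repeat measurement.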

Compound 4, area under the concentration-time curve: 2900 ng.h/mL
Beside the measured number, compound 4's estimate is 3.1-fold (0.49 log units) above it; measured number below the stated range.
By their numbers in this assay, from the lowest: compounds 4 and 1 (each within the scatter of the next); then compounds 2 and 3 (each within the scatter of the next).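

The place on a double-bonded chain carbon bound to a double-bonded chain carbon and a saturated chain carbon now has a measured step of its own: in this assay, 2-chloro-4-cyanophenyl in place of 3-chlorophenyl gives a 3.8-fold lower number from compound 3 to compound 4 (0.58 log units; beyond the scatter) on the shared core. Within the data shown here, the earlier single-place step, a 3.1-fold higher number from compound 1 to compound 2 (0.50 log units; beyond the scatter), belongs to a different group at a different place, so this is the first reading showing that the group at this place can also move oral exposure beyond the scatter. No measurement at hand bears on why the number falls with this change.

The step combines a nitrile with a new chlorine placement, and the compounds shown do not separate the two; readings for 4-cyanophenyl and 2-chlorophenyl at this same place would divide it. Also open, on these data alone, is whether the same replacement gives a step of similar size on the cores of compound 1 and compound 2, which differ from the core of compound 3 at the other group.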